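The compounds below may be only part of what the source reports. "The series", "measured", "known", "first", "only" and "open" are said of these compounds alone.

Series notes. Compound 1 `Nc1cccc(-c2cn(CC(=O)Nc3nc4ccccc4s3)nn2)c1` gives 1110 nM in a functional assay on BMDM cells (Mus musculus, strain C57BL/6) for inhibition, with a stated time of 2 days; on this read-out higher numbers stand for weaker inhibition and lower numbers for stronger inhibition. Compound 3 `COc1ccc(-c2cn(CC(=O)Nc3nc4ccccc4s3)nn2)cc1` gives 1330 nM in this assay; the step of a 1.2-fold higher number from compound 1 to compound 3 (0.08 log units; within the scatter) is small. For compound 2 `O=C(Cn1cc(-c2ccccc2Cl)nn1)Nc1nc2ccccc2s1` this assay reports only a limit, > 30000 nM. Against that limit the step of an at least 27-fold higher number from compound 1 to compound 2 (1.43 log units; beyond the scatter) is large, as is an at least 22-fold lower number from compound 2 to compound 3 (1.35 log units; beyond the scatter); both depend on the limit (the limit of > 30000 nM in this assay, at which 1 of the 3 values shown sits). Of the two actual numbers shown, compound 3 holds the higher one, though its gap to compound 1 lies within the scatter.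

Compound 4 `COC(=O)c1ccc(-c2cn(CC(=O)Nc3nc4ccccc4s3)nn2)cc1` is not yet measured. Relative to compound 3 it carries methoxycarbonyl in place of methoxy on an aromatic carbon. For the measured compounds named here, the only measured step that exchanges one substituted phenyl for another without loss is the one from compound 1 to compound 3, which stayed within the scatter; the large steps both involve 2-chlorophenyl, a different kind of change. Going by the values given here, no measured step swaps methoxy for methoxycarbonyl, so the expectation rests on the tolerance seen so far. Compound 4 is therefore expected to show at most a modest step, a 1.5-fold higher number from compound 3 to compound 4 (0.18 log units; within the scatter), leaning slightly weaker. Compound 4 is estimated at 2000 nM, with a range of 700 nM to 6000 nM.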

Compound 4, half-maximal inhibitory concentration: > 30000 nM
Compound 4 gave a limit, no number; the forecaster's own chance of this, stated with the estimate: 10%; middle value at least 15-fold (1.17 log units) from the limit.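

In this assay, the step of an at least 22-fold higher number from compound 3 to compound 4 (1.35 log units; beyond the scatter) shows that the place para to a large group is not open to any substituent: methoxycarbonyl there gives up the measurable activity that methoxy keeps. Until now, the only large losses involved 2-chlorophenyl, so this second one shows that such a loss is not confined to that group and can follow a change at this place alone. The size of the step is only a lower bound, and the same limit now covers two compounds: the limit of > 30000 nM in this assay, at which 2 of the 4 values shown sit.

From the compounds shown here alone, how far compound 4 lies beyond its limit stays unknown, and no order can be read between compounds 2 and 4. Going by these compounds, it also remains open whether a carboxylic acid, a primary amide or an ethoxy group at this place would give a number, so the feature of methoxycarbonyl behind the loss cannot yet be identified.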